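Trimming the side group of compound 2

A few compounds are considered here, and "the series" means these few. Any claim that something is new, unique, unknown or untested is made for them only; others in the source may bear on it.

Within the data shown here, in a functional assay (aorta) with Rattus norvegicus as the target (a higher number here means that more compound is needed for the effect, a lower number that less compound is needed), compound 2 `COc1ccc(-c2nc(CNC(=O)N3CCOCC3)sc2-c2ccc(OC)cc2)cc1` gives 12 uM, the only true number so far. Compound 1 `COc1ccc(-c2nc(/N=C(\N)NC3CCCCC3)sc2-c2ccc(OC)cc2)cc1` stands at > 100 uM, which is a limit of the assay and not a number.

Compound 3 `COc1ccc(-c2nc(C(=O)N(C)C)sc2-c2ccc(OC)cc2)cc1` carries dimethylcarbamoyl in place of (((morpholin-4-yl)carbonyl)amino)methyl on an aromatic carbon of the shared core: dimethylcarbamoyl in place of (((morpholin-4-yl)carbonyl)amino)methyl on an aromatic carbon.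

Among the measured compounds shown here, one measured step bears on this place: an at least 8.3-fold lower number from compound 1 to compound 2 (0.92 log units; beyond the scatter). It shows that swapping the group here can move the reading in this assay by a clear margin. That step rests on a limit, however, and neither of its groups is dimethylcarbamoyl, so it gives only a loose guide to size and none to direction.

Only a small upward move is expected, a 1.7-fold higher number from compound 2 to compound 3 (0.22 log units; within the scatter). For compound 3 the estimated value is 20 uM, with an expected range from 5 uM to 80 uM.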

Compound 3, concentration for half-maximal effect: 3 uM
Beside the measured number, compound 3's estimate is 6.7-fold (0.82 log units) above it; the whole stated range lies above it.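

In this assay, among these compounds, putting dimethylcarbamoyl in place of (((morpholin-4-yl)carbonyl)amino)methyl gives a 4.0-fold lower number from compound 2 to compound 3 (0.60 log units; beyond the scatter), the first comparison at this position between two true numbers. It shows that neither the morpholine ring nor the hydrogen-bond donor of the leaving group is needed for a reading at this level, and that the smaller group without a ring does better here. The widest gap is an at least 33-fold lower number from compound 1 to compound 3 (1.52 log units; beyond the scatter), but compound 1 sits at a limit of the assay and not at a number, so that size is only a bound: the limit of > 100 uM in this assay, at which 1 of the 3 values shown sits.

The compounds shown leave open which part of dimethylcarbamoyl accounts for the lower number, and whether a carboxylic acid or an amine on this aromatic carbon would read alike. They also do not tell which way a longer chain here would move the reading in this assay.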